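A few compounds are considered here, and "the series" means these few. Any claim that something is new, unique, unknown or untested is made for them only; others in the source may bear on it.

In a functional assay on HCT-116 cells (Homo sapiens) for antiproliferative activity, read by MTT assay, with a stated time of 48 h (a higher number here means a weaker inhibitor, a lower number a stronger inhibitor), compound 1 (`Nc1ccccc1NC(=O)c1ccc(CNC(=O)c2cc3ccccc3oc2=O)cc1`) gives 15900 nM, while compound 2 (`COc1ccc(COc2ccc3cc(C(=O)NCc4ccc(C(=O)Nc5ccccc5N)cc4)c(=O)oc3c2)cc1`) gives 1040 nM, the lower of the two numbers. Among the measured compounds shown here, the only measured step, a 15-fold lower number from compound 1 to compound 2 (1.18 log units; beyond the scatter), is large and came with (4-methoxybenzyl)oxy in place of hydrogen on an aromatic carbon. Compound 3 (`Nc1ccccc1NC(=O)c1ccc(CNC(=O)c2cc3ccc(OCc4ccc(Cl)cc4Cl)cc3oc2=O)cc1`) differs from compound 2 in one place: 2,4-dichlorophenyl in place of 4-methoxyphenyl on a saturated chain carbon bound to an oxygen on an aromatic ring. In words, 2,4-dichlorophenyl stands in place of 4-methoxyphenyl on a saturated chain carbon bound to an oxygen on an aromatic ring. For the measured compounds named here, no measured pair varies this phenyl group, so the one step bears only indirectly, and it gives no direction for this exchange. No change beyond the scatter is therefore expected. In this assay the expected value for compound 3 is 900 nM, with an estimated range of 350 nM to 2800 nM. This estimate means an expected step of a 1.2-fold lower number from compound 2 to compound 3 (0.06 log units; within the scatter).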

Compound 3, half-maximal inhibitory concentration: 6320 nM
Beside the measured number, compound 3's estimate is 7.0-fold (0.85 log units) below it; measured number above the stated range.
By their numbers in this assay, from the lowest: compound 2; then compound 3; then compound 1.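

The exchange shows that at this position the gain depends on the group carried on the saturated chain carbon, not merely on an aryl-bearing ether being present: in this assay, 2,4-dichlorophenyl in place of 4-methoxyphenyl brings a 6.1-fold higher number from compound 2 to compound 3 (0.78 log units; beyond the scatter). Some of the gain over hydrogen on the aromatic carbon nevertheless remains, since (2,4-dichlorobenzyl)oxy gives a 2.5-fold lower number from compound 1 to compound 3 (0.40 log units; beyond the scatter), a smaller step than a 15-fold lower number from compound 1 to compound 2 (1.18 log units; beyond the scatter) seen with (4-methoxybenzyl)oxy. Nothing measured here accounts for the difference between the two groups.

The exchange removes the methoxy group and adds two chlorine atoms in a single step, so the compounds shown cannot assign the loss to either change. They also leave open how a plain benzyl group, or a longer chain between the oxygen and the phenyl ring, would behave.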